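Two Urea Esters Compared for Microsomal Stability

A few compounds are considered here, and "the series" means these few. Any claim that something is new, unique, unknown or untested is made for them only; others in the source may bear on it.

Compound 1, `CCCCc1cn(-c2ccc(NC(=O)Nc3cc(OC4CCCC4)ccc3C)cc2)nn1`: 92.5%
Compound 2, `CC(C)CC(=O)OCCc1cn(-c2ccc(NC(=O)Nc3ccccc3C(F)(F)F)cc2)nn1`: 49.3%

Of the compounds shown here, two have been measured in an ADME assay on microsomes from liver (Homo sapiens) for metabolic stability, with a stated time of 60 min; on this read-out higher numbers stand for a more stable compound and lower numbers for a less stable compound. Compound 1 gives 92.5% in this assay, and compound 2 gives 49.3%. Compound 2 stands lowest of the two numbers, with compound 1 higher by a margin beyond the usual scatter. The two differ in several places at once, so the pair says nothing about any single change.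

Compound 3, `CCOC(=O)CCc1cn(-c2ccc(NC(=O)Nc3ccccc3C(F)(F)F)cc2)nn1`, is not yet measured. It differs from compound 2 in one place: ethoxycarbonyl in place of (isobutylcarbonyl)oxy on a saturated chain carbon, two bonds along the chain from an aromatic carbon. Going by the values given here, both compounds carry an ester two bonds along the chain from the aromatic carbon, and no measured pair separates the effect of this swap. Compound 3 is therefore expected to land near compound 2, with a step of a number 5.7 percentage points higher from compound 2 to compound 3 (within the scatter), not clearly beyond the scatter. The estimate for compound 3 in this assay is 55%, with a range from 30% to 80%.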

Compound 3, percent of the compound remaining: 16.9%
Beside the measured number, compound 3's estimate is 38.1 percentage points above it; the measured number lies below the stated range.
By their numbers in this assay, from the lowest: compound 3; then compound 2; then compound 1.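

At this position, on a saturated chain carbon two bonds along the chain from an aromatic carbon, the change from (isobutylcarbonyl)oxy to ethoxycarbonyl is far from neutral in this assay, with a step of a number 32.4 percentage points lower from compound 2 to compound 3 (beyond the scatter). Going by these compounds alone, this is the first change in one place among the compounds, and it shows that this side chain alone can move the read-out by a large amount, although both groups have the same counts of double bonds, hydrogen-bond donors and acceptors. Nothing available explains why the number falls.

This single pair cannot show which part of the swap carries the step, and it comes from one shared core only. Going by these compounds, how a carboxylic acid, an amine or a longer chain on this carbon would read in this assay remains open.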